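Exchanging the amide substituent in a liver clearance series

The compounds below may be only part of what the source reports. "The series", "measured", "known", "first", "only" and "open" are said of these compounds alone.

The measured compounds:
compound 1 `O=C(CCSc1nc2cc(Cl)ccc2o1)NC1CCCC1`: 11.3 mL/min/g
compound 2 `O=C(CCSc1nc2ccncc2o1)N1CCCC1`: 0.9 mL/min/g
compound 3 `O=C(CCSc1nc2ccc(Cl)cc2o1)N1CCCC1`: 6.6 mL/min/g

Three compounds built on a shared core have been examined in an ADME assay on microsomes from liver (Homo sapiens) for metabolic stability, read by LC-MS, using NADPH, with a stated time of 45 min, tested at 0.5 uM; on this read-out higher numbers stand for fast clearance and lower numbers for slow clearance. Compound 1 gives the highest of the three numbers. Compound 3 lies nearest to it, and the gap between them is within the usual scatter, so no order is read between these two. Compound 2 lies furthest from compound 1, and that gap is beyond the scatter.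

Compound 4 `CC1CCCN1C(=O)CCSc1nc2cc(Cl)ccc2o1` has not yet been measured. It differs from compound 1 by 2-methylpyrrolidin-1-yl in place of cyclopentylamino on a carbonyl carbon. Going by the values given here, no step between measured compounds differing in a single place is available, so the size of this change cannot be read directly from the measurements. Among the compounds with values here, the only pointer is that compound 3, which also carries a ring on the amide nitrogen, sits within the scatter of compound 1. In this assay compound 4 is therefore expected to remain close to compound 1, with a step of a 1.2-fold lower number from compound 1 to compound 4 (0.08 log units; within the scatter) that is not expected to exceed the scatter. The estimate for compound 4 is 9.5 mL/min/g, with a range from 5 mL/min/g to 18 mL/min/g.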

Compound 4, intrinsic clearance in a liver preparation (reported as CLH), per the amount of preparation that the assay uses: 8.5 mL/min/g
Beside the measured number, compound 4's estimate is 1.1-fold (0.05 log units) above it; the range from low to high includes it.
By their numbers in this assay, from the lowest: compound 2; then compounds 3, 4 and 1 (each within the scatter of the next).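

In this assay, going by these compounds alone, the exchange of cyclopentylamino for 2-methylpyrrolidin-1-yl on a carbonyl carbon gives the first direct reading of a change at this position: a 1.3-fold lower number from compound 1 to compound 4 (0.12 log units; within the scatter). The amide hydrogen is absent from compound 4 and the heavy-atom count of the group is unchanged, yet with the rest of the structure held fixed, the clearance numbers of the pair cannot be told apart. Nothing measured here bears on why the two numbers stay together.

This single pair leaves open whether a morpholine ring, a piperidine ring or an open-chain diethylamino group on the same carbonyl carbon would also stay within the scatter of compound 1. Compounds 2 and 3 differ from compound 1 in more than one place, and what the amide substituent does on their cores remains unread.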